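The compounds below may be only part of what the source reports. "The series", "measured", "known", "first", "only" and "open" are said of these compounds alone.

Three compounds have numbers in an assay on HEK293 cells for agonist activity at transient receptor potential cation channel subfamily M member 8 (Homo sapiens), read by fluorescence and calcium flux, with a stated time of 15 min; on this read-out higher numbers stand for an effect only at larger amounts of compound and lower numbers for an effect already at smaller amounts. Compound 1 `CCN(Cc1cccn1C)C(=O)COc1ccc(C)cc1` gives 21300 nM, compound 2 `Cc1ccc(OCC(=O)N(C)Cc2cccs2)cc1` gives 400 nM, and compound 3 `CCN(Cc1cccs1)C(=O)COc1cc(C)ccc1O` gives 24 nM. Compound 2 thus stands second highest of the three, far from compound 3 on the lower side and far from compound 1 on the higher side, both gaps beyond the scatter. Going by the values given here, no step between measured compounds that differ in a single place is available, so the record gives no direct guide to changes on the amide-type nitrogen. Compound 4 `Cc1ccc(OCC(=O)N(Cc2cccs2)c2ncco2)cc1` arises from compound 2 by 1,3-oxazol-2-yl in place of methyl on an amide-type nitrogen. A modest weakening is expected, so that the step is estimated as a 3.8-fold higher number from compound 2 to compound 4 (0.57 log units; beyond the scatter). For compound 4 the estimate in this assay is 1500 nM, within a wide range from 200 nM to 12000 nM.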

Compound 4, half-maximal effective concentration: 0.3 nM
Estimate against measurement, compound 4: 5000-fold (3.70 log units) above; measured number below the stated range.
By their numbers in this assay, from the lowest: compound 4; then compound 3; then compound 2; then compound 1.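

On the amide-type nitrogen, the substituent is not a minor detail: in this assay, 1,3-oxazol-2-yl in place of methyl gives a large step (a 1300-fold lower number from compound 2 to compound 4 (3.12 log units; beyond the scatter)). Going by these compounds alone, the position therefore accepts a five-membered aromatic ring with two hetero atoms, and the earlier compounds gave no sign of a change of this size. Nothing available accounts for this step. The compounds shown leave open whether phenyl or a pyridine ring on the same nitrogen would behave like 1,3-oxazol-2-yl. On these data alone, whether the step would carry over to the cores of compound 1 or compound 3 also stays open.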